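A few compounds are considered here, and "the series" means these few. Any claim that something is new, unique, unknown or untested is made for them only; others in the source may bear on it.

Measured compounds in a functional assay on A549 cells (Homo sapiens) for antiproliferative activity, read by MTT assay, with a stated time of 72 h; on this read-out higher numbers stand for weaker inhibition and lower numbers for stronger inhibition:

Compound 1, `O=C(C1=C(O)C(=O)N(CCCn2ccnc2)C1c1ccc(Br)cc1)c1ccccc1`: 73100 nM
Compound 2, `CCOc1ccc(NC2=C(C(=O)c3ccccc3)C(c3ccc(Br)cc3)N(CCCn3ccnc3)C2=O)cc1`: 20200 nM
Compound 3, `O=C(C1=C(Nc2ccc(I)cc2)C(=O)N(CCCn2ccnc2)C1c1ccc(Br)cc1)c1ccccc1`: 24500 nM

Among these three, compound 3 and compound 2 cannot be told apart, since a 1.2-fold higher number from compound 2 to compound 3 (0.08 log units; within the scatter). Against compound 1, compound 3 gives a clearly lower number, a 3.0-fold lower number from compound 1 to compound 3 (0.47 log units; beyond the scatter), and the same kind of step shows up a 3.6-fold lower number from compound 1 to compound 2 (0.56 log units; beyond the scatter). Both of those steps replaced the hydroxy group with an arylamino group, whereas the step to compound 4 keeps that group and only alters its ring.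

Compound 4, `O=C(C1=C(Nc2ccc(Br)cc2)C(=O)N(CCCn2ccnc2)C1c1ccc(Br)cc1)c1ccccc1`, is compound 3 with one change: bromo in place of iodo on an aromatic carbon. Going by the values given here, no measured pair swaps one halogen for another. The nearest guide is the exchange of ethoxy for iodo on the same ring position, a 1.2-fold higher number from compound 2 to compound 3 (0.08 log units; within the scatter), which stayed within the scatter. On that basis no step beyond the scatter is expected in either direction, and the estimated change is a 1.0-fold higher number from compound 3 to compound 4 (0.01 log units; within the scatter). Compound 4 is therefore expected to give about 25000 nM in this assay, with a likely range from 10000 nM to 60000 nM.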

Compound 4, half-maximal inhibitory concentration: 22200 nM
Beside the measured number, compound 4's estimate is 1.1-fold (0.05 log units) above it; measured number inside the range.
By their numbers in this assay, from the lowest: compounds 2, 4 and 3 (each within the scatter of the next); then compound 1.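

In this assay, going by these compounds alone, one halogen replaces another on this aromatic carbon, para to a large group, for the first time: with bromo in place of iodo there is a 1.1-fold lower number from compound 3 to compound 4 (0.04 log units; within the scatter), so the two cannot be told apart. Bromo in place of ethoxy reads the same way, with a 1.1-fold higher number from compound 2 to compound 4 (0.04 log units; within the scatter), so iodo, ethoxy and bromo all give numbers within the scatter of one another, while the clear step remains the replacement of hydroxy by an arylamino group, here a 3.3-fold lower number from compound 1 to compound 4 (0.52 log units; beyond the scatter). No measurement at hand gives a reason for any of these steps.

As far as these compounds go, whether the number would hold with a different kind of group on this ring carbon, such as an amine or a carboxylic acid, stays open. So does whether a fluoro, or a plain hydrogen, in that place would read the same.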